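The source may hold more compounds than are shown below. What is called first, only, known or untested is meant among the compounds shown, and "the series" means these compounds.

Measured so far:
compound 1 `Fc1ccc(C(SCCNC2CCN(Cc3ccc(C(F)(F)F)cc3)CC2)c2ccc(F)cc2)cc1`: 190 nM
compound 2 `Fc1ccc(C(SCCNC2CCN(CC3CC3)CC2)c2ccc(F)cc2)cc1`: 407 nM

For the measured compounds named here, in an assay on membranes from striatum (strain Sprague-Dawley) for displacement of a labelled ligand from sodium-dependent dopamine transporter (Rattus norvegicus), read by scintillation counting, with a stated time of 120 min (on this read-out lower numbers stand for stronger inhibition and higher numbers for weaker inhibition), compound 2 gives the higher of the two numbers, and the only step known, a 2.1-fold higher number from compound 1 to compound 2 (0.33 log units; beyond the scatter), runs to it. Compound 3 `O=C(c1ccc(F)cc1F)N1CCC(NCCSC(c2ccc(F)cc2)c2ccc(F)cc2)CC1` is not yet measured; it differs from compound 2 by (2,4-difluorophenyl)carbonyl in place of cyclopropylmethyl on an amine nitrogen in a ring. That step bears on the same ring nitrogen as the measured one, where a larger aromatic group went with a lower number, so a modest lowering is expected in this assay, as a 1.2-fold lower number from compound 2 to compound 3 (0.07 log units; within the scatter), though the carbonyl is new here. Compound 3 is therefore estimated at 350 nM, within 100 nM to 1200 nM.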

Compound 3, inhibition constant: 30 nM
Compound 3: the middle estimate sits 12-fold (1.07 log units) above what was measured; the measured number lies below the stated range.
By their numbers in this assay, from the lowest: compound 3; then compound 1; then compound 2.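

This position responds far more strongly than the first pair suggested: swapping in (2,4-difluorophenyl)carbonyl goes with a 14-fold lower number from compound 2 to compound 3 (1.13 log units; beyond the scatter). An aromatic ring alone does not account for this, since compound 1 also carries one, yet the change still gives a 6.3-fold lower number from compound 1 to compound 3 (0.80 log units; beyond the scatter). Nothing measured here explains the gain.

The compounds shown do not separate the contribution of the carbonyl from that of the two fluorines. A 2,4-difluorobenzyl group or an unsubstituted benzoyl group on the same nitrogen would help to tell them apart.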